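The compounds below may be only part of what the source reports. "The series", "measured", "known", "first", "only" and "open" are said of these compounds alone.

Compound 1 `CCc1cc(S(=O)(=O)N2C[C@H](c3ccccc3)NC2=O)ccc1NC(=O)OC` is a sulfonyl-linked cyclic urea bearing a methoxycarbonyl amide on its aryl ring. In a functional assay on A549 cells (Homo sapiens) for cytotoxicity, read by MTT assay (a lower number here means a stronger inhibitor, a higher number a weaker inhibitor), compound 1 gives 250 nM, the higher of the two numbers recorded here. Compound 2 `CCOC(=O)Nc1ccc(S(=O)(=O)N2C[C@H](c3ccccc3)NC2=O)cc1C`, which carries an ethoxycarbonyl amide and a methyl instead of an ethyl on its ring, gives in this assay 50 nM, a lower number that lies beyond the usual scatter. Compound 3 `Cc1cc(S(=O)(=O)N2C(=O)N[C@@H](c3ccccc3)C2C)ccc1NC(=O)c1ccc([N+](=O)[O-])cc1` reaches only a limit of the assay, > 10000 nM, at which it sits (the limit of > 10000 nM in this assay, at which 1 of the 3 values shown sits).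

Compound 4 `CCc1cc(S(=O)(=O)N2C[C@H](c3ccccc3)NC2=O)ccc1NC(=O)OCC(C)C` differs from compound 1 by isopropyl in place of hydrogen on a saturated chain carbon bound to an oxygen next to a carbonyl group. Going by the values given here, no pair among the measured compounds shows the effect of lengthening this alkoxy arm alone, so the expectation for this step rests on nothing more than the numbers for compound 1 and compound 2. The step from compound 1 to compound 4 is expected to be small in this assay, with no change that is clearly beyond the scatter no change at the digits printed from compound 1 to compound 4 (within the scatter). For compound 4 the estimated value in this assay is 250 nM, with a range from 80 nM to 800 nM.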

Compound 4, half-maximal inhibitory concentration: 70 nM
Estimate against measurement, compound 4: 3.6-fold (0.55 log units) above; measured number outside the range, below it.
By their numbers in this assay, from the lowest: compounds 2 and 4 (each within the scatter of the next); then compound 1. At a limit, above all of these: compound 3.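

Replacing methoxycarbonyl with isobutoxycarbonyl, with the rest of the molecule unchanged, gives a 3.6-fold lower number from compound 1 to compound 4 (0.55 log units; beyond the scatter) in this assay. This is the first pair shown that differs in this one place, and it shows that the saturated chain carbon bound to an oxygen next to a carbonyl group can carry an isopropyl without the number rising; here it falls. Nothing measured here accounts for this step.

On these data alone, a single step cannot show a trend along this arm, so it remains open whether the number would keep falling, level off or rise again with a longer chain such as hexyl or with a ring such as cyclohexyl. As far as these compounds go, an amine at the end of the arm is equally open.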